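Hexyl to Azido on the Fluorinated Core: an Expected Value

A few compounds are considered here, and "the series" means these few. Any claim that something is new, unique, unknown or untested is made for them only; others in the source may bear on it.

Compound 1 `CCCCCCc1c(F)c(N)c2c(=O)cc(-c3ccc(N)c(F)c3)oc2c1F`: 21000 nM
Compound 2 `Nc1ccc(-c2cc(=O)c3c(N)c(F)c(O)c(F)c3o2)cc1F`: > 100000 nM, a limit of the assay
Compound 3 `Nc1ccc(-c2cc(=O)c3c(N)c(F)c(CO)c(F)c3o2)cc1F`: 24000 nM

In a functional assay on HeLa cells (Homo sapiens) for cytotoxicity, read by neutral red uptake, with a stated time of 3 days (a lower number here means a stronger inhibitor, a higher number a weaker inhibitor), compound 1 and compound 3 give numbers within the scatter of each other, a 1.1-fold higher number from compound 1 to compound 3 (0.06 log units; within the scatter). For compound 2 the assay reports only a limit, > 100000 nM.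

Compound 4 `[N-]=[N+]=Nc1c(F)c(N)c2c(=O)cc(-c3ccc(N)c(F)c3)oc2c1F` differs from compound 1 by azido in place of hexyl on an aromatic carbon. Within the data shown here, two measured steps touch the same aromatic carbon: an at least 4.7-fold higher number from compound 1 to compound 2 (0.67 log units; beyond the scatter), and an at least 4.1-fold lower number from compound 2 to compound 3 (0.61 log units; beyond the scatter). The first is known only as a limit, (the limit of > 100000 nM in this assay, at which 1 of the 3 values shown sits). Replacing the long chain with a small group thus weakened cytotoxicity once and left it unchanged once, so a moderate rise in the number is expected for compound 4, a 2.1-fold higher number from compound 1 to compound 4 (0.33 log units; beyond the scatter). Compound 4 is estimated at 45000 nM, with a range from 15000 nM to 150000 nM.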

Compound 4, half-maximal inhibitory concentration: 1200 nM
Beside the measured number, compound 4's estimate is 38-fold (1.57 log units) above it; measured number outside the range, below it.
By their numbers in this assay, from the lowest: compound 4; then compounds 1 and 3 (each within the scatter of the next). At a limit, above all of these: compound 2.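

At this aromatic carbon, ortho to two fluoro groups, azido gives the first large fall in the number in this assay, with an 18-fold lower number from compound 1 to compound 4 (1.24 log units; beyond the scatter) and a 20-fold lower number from compound 3 to compound 4 (1.30 log units; beyond the scatter). Against compound 1, the earlier replacements of hexyl left the number level or raised it, so a hexyl chain is not required for cytotoxicity in this series. The step to compound 2 rests on a limit of the assay, an at least 83-fold lower number from compound 2 to compound 4 (1.92 log units; beyond the scatter): the limit of > 100000 nM in this assay, at which 1 of the 4 values shown sits.

Going by these compounds, whether the fall is specific to azido, or would also come with an amine or a nitrile at this carbon, stays open. So does whether it persists with a hydrogen in place of either fluoro group.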